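This account rests on a few compounds, and the source may have more. Where it says the series, first, only, none or still open, it means among the compounds named here.

Compound 2 `COc1ccccc1-c1ncnn1-c1cc(OC)c(OC)c(OC)c1` belongs to a small set of three close relatives, all tested in a functional assay on HL-60 cells (Homo sapiens) for antiproliferative activity, read by MTT assay, with a stated time of 72 h; a lower number here means a stronger inhibitor, a higher number a weaker inhibitor. In this assay compound 2 gives > 10000 nM, which is a limit of the assay rather than a measured number. Compound 1 `COc1cc(-n2ncnc2-c2cccc([N+](=O)[O-])c2)cc(OC)c1OC` gives > 10000 nM in this assay, again only a limit. Compound 3 `CCOc1ccccc1-c1ncnn1-c1cc(OC)c(OC)c(OC)c1` gives > 10000 nM in this assay, once more a limit. For the measured compounds named here, the one step between measured neighbours, a step that the two limits leave unreadable from compound 2 to compound 3, therefore cannot be read, and the limit of > 10000 nM in this assay, at which 3 of the 3 values shown sit, sums up what the set shows: none of the three compounds reaches a measurable number.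

Compound 4 `COc1cc(-n2ncnc2-c2ccc(Cl)cc2)cc(OC)c1OC` is the next member. Its difference from compound 2 is 4-chlorophenyl in place of 2-methoxyphenyl on an aromatic carbon. Going by the values given here, no measured step covers this kind of exchange, so nothing in the data points to a gain or a loss beyond the usual scatter. With every measured relative sitting at the limit, as the limit of > 10000 nM in this assay, at which 3 of the 3 values shown sit, records, compound 4 is expected to remain a weak inhibitor as well. The step that the limit leaves unreadable from compound 2 to compound 4 is expected to be small and unresolved. Compound 4 is estimated at about 15000 nM, within a range from 3000 nM to 60000 nM, most likely reported only as a limit.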

Compound 4, half-maximal inhibitory concentration: > 10000 nM
Compound 4 was reported as a limit; the forecaster's own chance of this, stated with the estimate: 70%; the middle value does not contradict the limit.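

For the compounds shown here, compound 2 and compound 4 are both reported only as limits, so the exchange of 2-methoxyphenyl for 4-chlorophenyl gives no step that can be read. The compounds shown leave open how strongly each one inhibits and which change to the shared core would give a measurable number, as all remain at one limit: the limit of > 10000 nM in this assay, at which 4 of the 4 values shown sit.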